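A few compounds are considered here, and "the series" means these few. Any claim that something is new, unique, unknown or untested is made for them only; others in the source may bear on it.

Compound 2 `c1ccc2c(-c3cn4ccnc4c(-c4ccc5ncn(C6CCCCC6)c5c4)n3)cccc2c1` has been measured in a physicochemical assay for lipophilicity, using the shake flask method, in phosphate buffer, measured as octanol-water partition, with a stated time of 85 min, at pH 7.4 (on this read-out lower numbers stand for lower lipophilicity and higher numbers for higher lipophilicity), where compound 2 gives 1.44. Compound 1 `c1ccc(-c2cn3ccnc3c(-c3ccc4ncn(C5CCCCC5)c4c3)n2)cc1` gives 1.74 and compound 3 `Clc1ccc(-c2cn3ccnc3c(-c3ccc4ncn(C5CCCCC5)c4c3)n2)cc1` gives 1.51; the steps of a number 0.30 log units lower from compound 1 to compound 2 (within the scatter) and a number 0.07 log units higher from compound 2 to compound 3 (within the scatter) both sit inside the scatter, so these three numbers cannot be told apart. Compound 4 `Fc1ccccc1-c1cn2ccnc2c(-c2ccc3ncn(C4CCCCC4)c3c2)n1` differs from compound 2 in one place: 2-fluorophenyl in place of naphthalen-1-yl on an aromatic carbon. The step of a number 0.30 log units lower from compound 1 to compound 2 (within the scatter) bears on this, as it exchanges phenyl for naphthalen-1-yl, and the step of a number 0.23 log units lower from compound 1 to compound 3 (within the scatter) shows a halogen on that phenyl ring changing little. On this basis the step of a number 0.21 log units higher from compound 2 to compound 4 (within the scatter) is expected, nothing beyond the scatter. Compound 4 is therefore estimated at 1.65, in a range from 1.3 to 2.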

Compound 4, partition coefficient: 1.95
Compound 4: the middle estimate sits 0.30 log units below what was measured, and the stated range covers the measured number.
By their numbers in this assay, from the lowest: compounds 2, 3, 1 and 4 (each within the scatter of the next, the first and the last beyond it).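

Replacing groups at this position in this assay now gives the first differences beyond the scatter: 2-fluorophenyl in place of naphthalen-1-yl gives a number 0.51 log units higher from compound 2 to compound 4 (beyond the scatter), and 2-fluorophenyl in place of 4-chlorophenyl gives a number 0.44 log units higher from compound 3 to compound 4 (beyond the scatter). Fluoro in place of hydrogen, by contrast, stays inside the scatter, at a number 0.21 log units higher from compound 1 to compound 4 (within the scatter). No measurement shown explains these differences. Still open, going by these compounds, is how the number would respond to an amine or a carboxylic acid on the phenyl ring in place of a halogen.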